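Removing the chloro from an acylguanidine sulfonyl benzamide

The source may hold more compounds than are shown below. What is called first, only, known or untested is meant among the compounds shown, and "the series" means these compounds.

Two compounds carrying a guanidine-bearing amide and a methylsulfonyl group on a shared core have been examined. Compound 1 `Cc1ccc(-c2ccc(C(=O)N=C(N)N)cc2S(C)(=O)=O)cc1` gives 100 nM in a functional assay for inhibition of sodium/hydrogen exchanger (Oryctolagus cuniculus); a higher number here means a weaker inhibitor, a lower number a stronger inhibitor. Compound 2 `CS(=O)(=O)c1cc(C(=O)N=C(N)N)c(Cl)cc1-n1ccnc1`, which carries an imidazolyl group in place of the tolyl ring, gives 130 nM in this assay. Compound 2 stands with the higher of the two numbers, but its gap to compound 1 lies within the usual scatter, so the two cannot be ranked against each other.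

Compound 3 `CS(=O)(=O)c1cc(C(=O)N=C(N)N)ccc1-n1ccnc1` has not yet been measured. It differs from compound 2 by hydrogen in place of chloro on an aromatic carbon. Among the compounds with values here, no comparable step between measured compounds is available, so the expectation rests on the structural change alone. Loss of the chloro is expected to give a modest rise in the number, by a 2.3-fold higher number from compound 2 to compound 3 (0.36 log units; beyond the scatter), and compound 3 is accordingly estimated at 300 nM in this assay, within a range from 120 nM to 800 nM.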

Compound 3, half-maximal inhibitory concentration: 150 nM
Compound 3: the middle estimate sits 2.0-fold (0.30 log units) above what was measured; the measured number falls inside the stated range.
By their numbers in this assay, from the lowest: compounds 1, 2 and 3 (each within the scatter of the next).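

Putting hydrogen in place of the chloro, on the aromatic carbon para to the methylsulfonyl group, gives a 1.2-fold higher number from compound 2 to compound 3 (0.06 log units; within the scatter) in this assay, so losing this chloro brings no change that can be told from the scatter. The other step isolates a second place, which the earlier pair could not do, since compounds 1 and 2 differ in two places: 1H-imidazol-1-yl in place of 4-methylphenyl gives a 1.5-fold higher number from compound 1 to compound 3 (0.18 log units; within the scatter) and again no readable change. No measurement here accounts for either result.

From the compounds shown here alone, whether this aromatic carbon accepts more than hydrogen and chloro stays open, since a methoxy group, an amine or a carboxylic acid there might read differently. Going by these compounds, it is equally open whether a morpholine in place of the 1H-imidazol-1-yl group would hold the number.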